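The source may hold more compounds than are shown below. What is called first, only, known or untested is meant among the compounds shown, and "the series" means these compounds.

All three measured compounds share one core and differ only in the aromatic group carried on the amide-type nitrogen. Compound 1 `COc1ccc2nc(C)cc(OCC(=O)Nc3ccccc3)c2c1` carries a plain phenyl there and, in a toxicity assay on HepG2 cells (Homo sapiens) for inhibition, read by CellTiter-Glo, with a stated time of 48 h (a lower number here means a stronger inhibitor, a higher number a weaker inhibitor), compound 1 gives 39800 nM. Compound 2 `COc1ccc2nc(C)cc(OCC(=O)Nc3cc(C)ccc3C)c2c1` carries a 2,5-dimethylphenyl. In this assay compound 2 reaches only the limit of the assay, > 100000 nM, which is not a number. Compound 3 `COc1ccc2nc(C)cc(OCC(=O)Nc3cc(C)ccc3OC)c2c1` carries a 2-methoxy-5-methylphenyl. In this assay compound 3 likewise reaches only the limit, > 100000 nM. Both substituted anilides thus sit at the limit of > 100000 nM in this assay, at which 2 of the 3 values shown sit, so compound 3 stands at a limit rather than at a measured number. The change gave an at least 2.5-fold higher number from compound 1 to compound 2 (0.40 log units; beyond the scatter) and an at least 2.5-fold higher number from compound 1 to compound 3 (0.40 log units; beyond the scatter), whereas a step that the two limits leave unreadable from compound 2 to compound 3.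

Compound 4 `COc1ccc2nc(C)cc(OCC(=O)Nc3cc(C)c(F)c(C)c3)c2c1` is the next compound, and it differs from compound 3 by 4-fluoro-3,5-dimethylphenyl in place of 2-methoxy-5-methylphenyl on an amide-type nitrogen. The measured steps that bear on this are the two moves away from plain phenyl, each at least modest and each ending at the limit, and the move between the two substituted anilides, which cannot be read. Compound 4 again carries a substituted phenyl on that nitrogen, so the expectation is that it, too, stays near the limit. The expected step is a number no higher from compound 3 to compound 4 (the limit leaves the size open), which is no change beyond the scatter. For compound 4 the estimated value is 100000 nM, between 40000 nM and 300000 nM.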

Compound 4, half-maximal inhibitory concentration: > 100000 nM
Compound 4 ended at the assay's limit (the forecaster's own chance of this, stated with the estimate: 60%); the middle value sits exactly at the limit.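

Replacing the plain phenyl with 4-fluoro-3,5-dimethylphenyl on the amide-type nitrogen gave an at least 2.5-fold higher number from compound 1 to compound 4 (0.40 log units; beyond the scatter), so the rise in this assay seen with the two earlier substituted phenyls also appears with a group that carries fluorine. The group leaving compound 3 counts a hydrogen-bond acceptor and the group entering compound 4 counts none, yet both compounds end at the limit, and the steps among compound 2, compound 3 and compound 4 cannot be read. Only compound 1, with its plain phenyl, gives an actual number, and none of the three substituted phenyls goes against this pattern, as all of them share one reading: the limit of > 100000 nM in this assay, at which 3 of the 4 values shown sit.

Going by these compounds, the limit hides how far compound 2, compound 3 and compound 4 lie from one another, so their order in this assay stays unknown. Also open, on these data alone, is whether a phenyl bearing an amine or a carboxylic acid, or a pyridine ring in place of the phenyl, would give a measurable number, and on which side of compound 1 it would fall.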